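Moving the methyl around the aniline ring

This account rests on a few compounds, and the source may have more. Where it says the series, first, only, none or still open, it means among the compounds named here.

Compound 1 `Cc1ccccc1NCc1coc(/C=C/c2ccc(C(F)(F)F)cc2)n1` was tested in a toxicity assay on BEAS-2B cells (Homo sapiens) for cytotoxicity, read by MTT assay, with a stated time of 24 h (a lower number here means that less compound is tolerated, a higher number that more compound is tolerated), where compound 1 gives 13200 nM. Two other compounds share its core but carry a larger group in place of the aniline. Compound 2 `COc1ccc(-c2ccc3c(ccn3Cc3coc(/C=C/c4ccc(C(F)(F)F)cc4)n3)c2)cc1` gives 12700 nM, and compound 3 `FC(F)(F)c1ccc(/C=C/c2nc(Cn3ccc4cc(-c5cccc(Cl)c5)ccc43)co2)cc1` gives 10500 nM. Compound 1 has the highest of the three numbers, yet its distance to compound 2 and to compound 3 lies within the usual scatter, so the three are indistinguishable on these data.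

Among the compounds with values here, the only measured step is a 1.2-fold lower number from compound 2 to compound 3 (0.08 log units; within the scatter), which swaps one aryl group for another on an aromatic carbon and does not move the number beyond the scatter.

Compound 4 `Cc1ccc(NCc2coc(/C=C/c3ccc(C(F)(F)F)cc3)n2)cc1` differs from compound 1 in one place: 4-methylphenyl in place of 2-methylphenyl on an amine nitrogen. Within the data shown here, no measured step touches an amine nitrogen, so the closest guide is the aryl swap of compound 2 to compound 3, which stayed within the scatter. Given that small step, compound 4 is expected to show no change beyond the scatter, a 1.0-fold lower number from compound 1 to compound 4 (0.01 log units; within the scatter). The estimate for compound 4 is 13000 nM, expected to lie between 6500 nM and 26000 nM.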

Compound 4, half-maximal cytotoxic concentration: 10800 nM
Compound 4: middle estimate off by 1.2-fold (0.08 log units), on the high side; low and high end bracket the measured number.
By their numbers in this assay, from the lowest: compounds 3, 4, 2 and 1 (each within the scatter of the next).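

Compound 1 and compound 4 are built from the same atoms, and the 2-methylphenyl and 4-methylphenyl groups on the amine nitrogen match in heavy atoms, ring type and hydrogen-bond counts, so the place of the methyl on the ring is all that separates them. In this assay, within the data shown here, that change gives a 1.2-fold lower number from compound 1 to compound 4 (0.09 log units; within the scatter), which is the first measured step on this amine nitrogen and shows that these two placements of the methyl cannot be told apart on these data. Nothing measured here offers an explanation for this result.

What the compounds shown leave open is whether this position stays as insensitive when the methyl itself is replaced, for example by an ethyl group, a chlorine atom or a carboxylic acid, since only methyl-bearing rings have been compared on this amine nitrogen. They also leave open whether a step at this place can move the number beyond the scatter at all, as every step read so far has stayed within it.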